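The source may hold more compounds than are shown below. What is called first, only, known or untested is meant among the compounds shown, and "the series" means these compounds.

Of the compounds shown here, two have been measured in a functional assay on the whole organism (strain Wistar) for inhibition, with Rattus norvegicus as the target, read by paw edema, with stated times of 30 min and 3 h, at a dose of 100 mg/kg by the oral route; on this read-out lower numbers stand for less inhibition and higher numbers for more inhibition at the one dose given (going by the name of the read-out). Compound 1 `CCCCNC(=O)c1cc(OC)n(-c2ccccc2)n1` gives 20.6% there, and compound 2 `COc1cc(C(=O)NC(C)C)nn1-c1ccccc1` gives 24.8%. Among the measured compounds shown here, the one step between them, a number 4.2 percentage points higher from compound 1 to compound 2 (within the scatter), comes with isopropyl in place of butyl on an amide-type nitrogen. Of the two numbers, that of compound 2 is the larger, with compound 1 the nearest, and the gap is within the scatter, so the two are not told apart.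

Compound 3 `COc1cc(C(=O)N2CCCC2)nn1-c1ccccc1` is not yet measured. It differs from compound 2 by pyrrolidin-1-yl in place of isopropylamino on a carbonyl carbon. For the measured compounds named here, the only measured step bears on it just indirectly: it too alters the substituent at the amide carbonyl, and it stayed within the scatter. Going by the values given here, no measured step removes the hydrogen-bond donor or closes the amide substituent into a five-membered ring, so the data give no ground for a step beyond the scatter in either direction. Compound 3 is therefore expected to give 22%, within a range of 8% to 38%. The step this estimate means, a number 2.8 percentage points lower from compound 2 to compound 3 (within the scatter), is expected to stay within the scatter.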

Compound 3, a percentage reported as inhibition, in the whole organism at one dose (the size of the read-out at that dose, not a potency): 29.2%
For compound 3 the middle estimate is 7.2 percentage points below the measured one; low and high end bracket the measured number.
By their numbers in this assay, from the lowest: compounds 1, 2 and 3 (each within the scatter of the next).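

In this assay, pyrrolidin-1-yl in place of isopropylamino on the carbonyl carbon takes away the amide hydrogen and closes the substituent into a five-membered non-aromatic ring, yet this step, a number 4.4 percentage points higher from compound 2 to compound 3 (within the scatter), does not separate the two compounds. The comparison with the open butylamino chain reads the same way, a number 8.6 percentage points higher from compound 1 to compound 3 (within the scatter), so at this position the three substituents are not told apart, and neither the amide hydrogen nor an open chain is shown to be needed for a read-out of this size at the one dose given. Nothing at hand offers an explanation for these numbers.

Open, from the compounds shown here alone, is whether any group on this carbonyl carbon can move the read-out beyond the scatter, for instance morpholin-4-yl, piperidin-1-yl or a longer chain on the amide nitrogen, or a carboxylic acid in place of the amide. Also open, going by these compounds, is how far the shared core itself matters, since all three compounds carry it unchanged and differ only in the group on the carbonyl carbon.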